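Notes on the step from compound 2 to compound 3

This account rests on a few compounds, and the source may have more. Where it says the series, first, only, none or still open, it means among the compounds named here.

Measured so far in a functional assay on HCT-116 cells (Homo sapiens) for cytotoxicity; a lower number here means a stronger inhibitor, a higher number a weaker inhibitor
Compound 1 `CC(C)=CCC/C(C)=C\CC/C(C)=C\Cc1c[nH]c([N+](=O)[O-])c1` with 9200 nM
Compound 2 `CC(C)=CCC/C(C)=C\CC/C(C)=C\Cc1cc[nH]c1` with 13700 nM

Compound 2 at 13700 nM lies within the scatter of compound 1 at 9200 nM and these two values set no order. Compound 3 `CC(C)=CCC/C(C)=C\CC/C(C)=C\Cc1ccc[nH]1` has not yet been measured. Its difference from compound 2 is 1H-pyrrol-2-yl in place of 1H-pyrrol-3-yl on a saturated chain carbon bound to a double-bonded chain carbon and reads as 1H-pyrrol-2-yl in place of 1H-pyrrol-3-yl on a saturated chain carbon bound to a double-bonded chain carbon. The two have the same atoms, joined differently.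

Going by the values given here, the only measured step is a 1.5-fold higher number from compound 1 to compound 2 (0.17 log units; within the scatter) and it stays within the scatter. Among the compounds with values here, that step puts hydrogen in place of nitro on an aromatic carbon, so it is a different kind of change, and no measured step tests the present one. The evidence is therefore thin. No step beyond the scatter is expected in this assay and no direction can be given. The expected step is a 1.1-fold lower number from compound 2 to compound 3 (0.06 log units; within the scatter) and this expectation rests on a 1.5-fold higher number from compound 1 to compound 2 (0.17 log units; within the scatter) alone. For compound 3 the estimated value is 12000 nM with an expected range from 6000 nM to 25000 nM in this assay.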

Compound 3, half-maximal inhibitory concentration: 24400 nM
Compound 3: the middle estimate sits 2.0-fold (0.31 log units) below what was measured; measured number inside the range.
By their numbers in this assay, from the lowest: compounds 1, 2 and 3 (each within the scatter of the next, the first and the last beyond it).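

In this assay, the exchange of 1H-pyrrol-3-yl for 1H-pyrrol-2-yl on a saturated chain carbon bound to a double-bonded chain carbon gives a 1.8-fold higher number from compound 2 to compound 3 (0.25 log units; within the scatter). Going by these compounds alone, the earlier step concerned only the loss of a nitro group, so this is the first reading of the point of attachment itself: the two rings have the same atoms, joined differently, and the change from (1H-pyrrol-3-yl)methyl to (1H-pyrrol-2-yl)methyl sets no order between the two compounds. With a single pair and a step within the scatter, the attachment point has no demonstrated bearing on the read-out in this assay, and no information is at hand that would explain the values.

The compounds shown leave open whether the ring contributes to the read-out at all, since all three carry the same long unsaturated chain and none replaces the ring with a different group, such as a carboxylic acid or an amine. Also open, from the compounds shown here alone, is how a shorter chain would read in this assay, and whether a nitro group on the 1H-pyrrol-2-yl ring would give a step beyond the scatter.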